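The source may hold more compounds than are shown below. What is called first, only, known or untested is meant among the compounds shown, and "the series" means these compounds.

Compound 3 `O=C(c1ccc2c(c1)OCCO2)C1CCN(Cc2coc(-c3ccccc3F)n2)CC1` stands where every measured member of the series stands. In an ADME assay on HEK293 cells (Homo sapiens) for cytotoxicity, read by MTT assay, with a stated time of 36 h (a higher number here means a weaker inhibitor, a lower number a stronger inhibitor), compound 3 gives > 150 ug/mL, which is a limit of the assay and not a number. Compound 1 `O=C(c1ccc2c(c1)OCCO2)C1CCN(Cc2coc(-c3ccccc3)n2)CC1` carries the plain phenyl. In this assay compound 1 gives > 150 ug/mL, likewise a limit of the assay. Compound 2 `O=C(c1ccc2c(c1)OCCO2)C1CCN(Cc2coc(-c3ccc(F)c(F)c3)n2)CC1` carries the 3,4-difluorophenyl. In this assay compound 2 gives > 150 ug/mL, again a limit. All three values thus sit at the limit of > 150 ug/mL in this assay, at which 3 of the 3 values shown sit, and the steps a step that the two limits leave unreadable from compound 1 to compound 2, a step that the two limits leave unreadable from compound 1 to compound 3 and a step that the two limits leave unreadable from compound 2 to compound 3 cannot be read in either size or direction.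

Compound 4 `O=C(c1ccc2c(c1)OCCO2)C1CCN(Cc2coc(-c3ccco3)n2)CC1` is the next member to be measured. Its change from compound 3 is furan-2-yl in place of 2-fluorophenyl on an aromatic carbon. Among the measured compounds shown here, no measured step bears directly on this exchange; the three that exist vary only the fluorine pattern on the phenyl, and none could be read because every value shown sits at the limit of > 150 ug/mL in this assay, at which 3 of the 3 values shown sit. Nothing in the measured compounds points to a step beyond the scatter in this assay, so the expectation for compound 4 is that it too reports the limit. The step from compound 3 to compound 4 is expected to be a step that the limit leaves unreadable from compound 3 to compound 4. Compound 4 is estimated at 200 ug/mL, within a range from 100 ug/mL to 400 ug/mL.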

Compound 4, half-maximal inhibitory concentration: > 150 ug/mL
Compound 4: only a limit was reported; the forecaster's own chance of this, stated with the estimate: 85%; the middle value lies beyond the limit too.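

In this assay compound 4 gives > 150 ug/mL, again a limit of the assay. No new step can be read between compound 4 and compounds 1, 2 or 3, in either size or direction: the limit of > 150 ug/mL in this assay, at which 4 of the 4 values shown sit.

The compounds shown leave open whether exchanging the aromatic group on the shared core changes the reading in this assay at all.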